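From Fluoro to Phenyl in a Cytotoxicity Series

The source may hold more compounds than are shown below. What is called first, only, known or untested is meant among the compounds shown, and "the series" means these compounds.

Of the compounds shown here, three sharing one core have been measured in an ADME assay on L929 cells (Mus musculus) for cytotoxicity, read by resazurin assay, with a stated time of 96 h; on this read-out lower numbers stand for higher toxicity in this test and higher numbers for lower toxicity in this test. Compound 1 (`CCc1ccc(OC/C(=N\NC(N)=S)c2ccc(Br)cc2)cc1`) is known only through a limit, < 25500 nM. Compound 2 (`CC(C)(C)c1ccc(OC/C(=N\NC(N)=S)c2ccc(Br)cc2)cc1`) gives 23800 nM. Compound 3 (`NC(=S)N/N=C(\COc1ccc(F)cc1)c1ccc(Br)cc1`) gives 52300 nM, the highest number in the set and so the lowest toxicity in this test.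

Compound 4 (`NC(=S)N/N=C(\COc1ccc(-c2ccccc2)cc1)c1ccc(Br)cc1`) has phenyl in place of fluoro on an aromatic carbon of compound 3: phenyl in place of fluoro on an aromatic carbon.

Within the data shown here, two measured steps bear on this change, both read in the opposite direction. Fluoro in place of ethyl gives an at least 2.0-fold higher number from compound 1 to compound 3 (0.31 log units; beyond the scatter), and fluoro in place of tert-butyl gives a 2.2-fold higher number from compound 2 to compound 3 (0.34 log units; beyond the scatter). Both lie beyond the scatter and are modest. Phenyl, like ethyl and tert-butyl, is a carbon group, so leaving fluoro is expected to bring a modest move to a lower number, towards compound 2 at 23800 nM. The expected change is a 2.5-fold lower number from compound 3 to compound 4 (0.40 log units; beyond the scatter). Compound 4 is estimated at 21000 nM, with an expected range of 9000 nM to 48000 nM.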

Compound 4, half-maximal cytotoxic concentration: 90800 nM
Estimate against measurement, compound 4: 4.3-fold (0.64 log units) below; the measured number lies above the stated range.
By their numbers in this assay, from the lowest: compound 2; then compounds 3 and 4 (each within the scatter of the next).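

In this assay, the carbon groups at this position do not behave as one set: phenyl in place of fluoro gives a 1.7-fold higher number from compound 3 to compound 4 (0.24 log units; within the scatter), so compound 4 cannot be told apart from compound 3, although the ethyl and tert-butyl compounds both stand apart from compound 3. Against those two alkyl groups the phenyl compound separates clearly, with a 3.8-fold higher number from compound 2 to compound 4 (0.58 log units; beyond the scatter) and an at least 3.5-fold higher number from compound 1 to compound 4 (0.55 log units; beyond the scatter). The second of these steps rests on a limit, not a number, for compound 1: the limit of < 25500 nM in this assay, at which 1 of the 4 values shown sits.

Going by these compounds, what remains open is whether this result belongs to the aromatic ring itself or to phenyl alone. On these data alone, how a benzyl group, a methoxy group or an amine at this position would read in this assay also stays unknown.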